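The compounds below may be only part of what the source reports. "The series", "measured", "known", "first", "only" and "open" are said of these compounds alone.

Working notes on the series. Compound 1 `COc1ccc2c(/C=C/C(=O)c3cc(N)c(OC)c(OC)c3)c[nH]c2c1` and compound 2 `COc1ccc2c(/C=C/C(=O)c3cc(N)c(OC)c(OC)c3)cn(C)c2c1` share one core; compound 3 `COc1ccc2c(/C=C(\C)C(=O)c3cc(OC)c(OC)c([Se]C)c3)cn(C)c2c1` and compound 4 `COc1ccc2c(/C=C(\C)C(=O)c3cc(OC)c(OC)c([Se]C)c3)c[nH]c2c1` share another. In a functional assay on A549 cells (Homo sapiens) for antiproliferative activity, read by MTT assay, with a stated time of 48 h (on this read-out higher numbers stand for weaker inhibition and lower numbers for stronger inhibition), compound 1 gives 193 nM, compound 2 gives 106 nM, and compound 3 gives 15 nM. Compound 3 thus stands lowest of the three measured numbers, and both gaps to it lie beyond the scatter.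

The change from compound 2 to compound 1 is hydrogen in place of methyl on an aromatic nitrogen, and its step is a 1.8-fold higher number from compound 2 to compound 1 (0.26 log units; within the scatter). The change from compound 3 to compound 4 is hydrogen in place of methyl on an aromatic nitrogen; the place is described in the same words for both pairs, so it is the same change. How the core of compound 2 differs from the core of compound 3 is not broken down here.

Compound 4 is still to be measured in this assay. The expected step of a 1.8-fold higher number from compound 3 to compound 4 (0.26 log units; within the scatter) is taken to match a 1.8-fold higher number from compound 2 to compound 1 (0.26 log units; within the scatter), which lay within the scatter. Compound 4 is therefore estimated at 27 nM, with a range from 10 nM to 70 nM.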

Compound 4, half-maximal inhibitory concentration: 8 nM
Beside the measured number, compound 4's estimate is 3.4-fold (0.53 log units) above it, and the stated range ends above it.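

In this assay, hydrogen in place of methyl on an aromatic nitrogen gives a 1.9-fold lower number from compound 3 to compound 4 (0.27 log units; within the scatter) on the core of compound 3, a step that stands against the earlier one on the core of compound 2. The same change therefore does not carry over from one core to the other as a single fixed step: the same change on two cores in this assay, a 1.8-fold higher number (0.26 log units; within the scatter) from compound 2 to compound 1 and a 1.9-fold lower number (0.27 log units; within the scatter) from compound 3 to compound 4, 3.4-fold (0.53 log units) apart, beyond the scatter of two such steps. Each step alone lies within the scatter, so the pairs show that the earlier step is a poor guide to the later one, but they do not show that the change has a real effect on either core, nor which difference between the cores sets the two steps apart.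

The compounds shown hold only hydrogen or methyl on that aromatic nitrogen, so it stays open how a longer chain or a carboxylic acid-bearing chain there would behave on either core. Going by these compounds, whether the gap between the two steps would recur on a further core also stays open.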